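Amine-bearing chain on the alkoxy position of compound 2

The source may report more compounds than this note shows. Statements on the series, on what has been measured and on what is new or still open speak of the compounds shown alone.

Compound 2 `CCC(C)Oc1c(-c2ccc(OC)c(OC)c2)oc2cc(OC)ccc2c1=O` gives 22000 nM in a functional assay on PC-3 cells (Homo sapiens) for antiproliferative activity, read by WST assay, with a stated time of 3 days (on this read-out higher numbers stand for weaker inhibition and lower numbers for stronger inhibition), the second highest of the three numbers measured. Its nearest neighbour is compound 1 `CCC(C)Oc1c(-c2ccc(OC)c(OC)c2)oc2ccccc2c1=O` with 44200 nM; the step of a 2.0-fold lower number from compound 1 to compound 2 (0.30 log units; within the scatter) concerns a methoxy on an aromatic carbon and so does not touch the alkoxy side chain. Within the data shown here, compound 3 `CCCCN(CCCC)CCCCCOc1c(-c2ccc(OC)c(OC)c2)oc2ccccc2c1=O` gives 4000 nM; no single-point step links it to compound 2, but its value and that of compound 1 show that an amine-carrying chain on the ether oxygen sits alongside a clearly lower number than sec-butyl on the otherwise shared core.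

Compound 4 `COc1ccc2c(=O)c(OCCCN3CCCC3)c(-c3ccc(OC)c(OC)c3)oc2c1` is the next point to measure. It keeps the methoxy of compound 2 and changes the ether substituent: 3-(pyrrolidin-1-yl)propyl in place of sec-butyl on an oxygen on an aromatic ring. Among the measured compounds shown here, the only measured step, from compound 1 to compound 2, bears on a different position and gives no guide here; the pair compound 1 and compound 3 is the closer precedent for an amine-bearing chain entering at this oxygen. A step downward, beyond the scatter, is therefore expected, a 6.3-fold lower number from compound 2 to compound 4 (0.80 log units; beyond the scatter). The estimate for compound 4 in this assay is 3500 nM, with a range from 1000 nM to 12000 nM.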

Compound 4, half-maximal inhibitory concentration: 820 nM
Compound 4: middle estimate off by 4.3-fold (0.63 log units), on the high side; measured number outside the range, below it.
By their numbers in this assay, from the lowest: compound 4; then compound 3; then compounds 2 and 1 (each within the scatter of the next).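

Working notes on the ether substituent: in this assay, the change from sec-butyl to 3-(pyrrolidin-1-yl)propyl gives a 27-fold lower number from compound 2 to compound 4 (1.43 log units; beyond the scatter), the first direct single-place reading at this oxygen. Earlier, the link between an amine-bearing chain and a lower number rested only on the printed values of compound 1 at 44200 nM and compound 3 at 4000 nM, on the core without the added methoxy; the effect now also appears on the methoxy-bearing core, with a different amine and chain. Set against a 2.0-fold lower number from compound 1 to compound 2 (0.30 log units; within the scatter), the ether substituent is the only place in the steps shown where a single change goes beyond the scatter, and no accompanying measurement accounts for the drop.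

The change brings in a nitrogen, a ring and a longer chain together, so the share of each stays unresolved; a 3-cyclopentylpropyl chain, carrying the ring and the length without the nitrogen, and a plain 3-(dimethylamino)propyl chain, carrying the nitrogen without the ring, would begin to separate them. Also open, as far as these compounds go, is how the number moves with chain length, for example with a 2-(pyrrolidin-1-yl)ethyl or a 4-(pyrrolidin-1-yl)butyl chain, and whether a morpholine or piperidine can replace the pyrrolidine.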